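Replacing the 5-carboxypyridin-3-yl group of compound 1

This account rests on a few compounds, and the source may have more. Where it says the series, first, only, none or still open, it means among the compounds named here.

Compound 1 `O=C(O)c1cncc(-n2cc(CO[C@H]3O[C@H](CO)[C@@H](O)[C@H](O)[C@@H]3O)nn2)c1` is the starting point for this step. In a physicochemical assay for solubility, read by LC-MS, using the shake flask method, measured as thermodynamic solubility, with a stated time of 24 h, at pH 6.5 (on this read-out lower numbers stand for lower solubility and higher numbers for higher solubility), compound 1 gives > 3000 ug/mL, which is a limit and not a number. Compound 2 `COc1ccc(Cn2cc(CO[C@H]3O[C@H](CO)[C@@H](O)[C@H](O)[C@@H]3O)nn2)cc1` gives > 3000 ug/mL in this assay, also a limit. The position of compound 1 is therefore defined only by the limit of > 3000 ug/mL in this assay, at which 2 of the 2 values shown sit, and no exact value anchors the comparison.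

Compound 3 `COc1ccc(-n2cc(CO[C@H]3O[C@H](CO)[C@@H](O)[C@H](O)[C@@H]3O)nn2)cc1` carries 4-methoxyphenyl in place of 5-carboxypyridin-3-yl on an aromatic nitrogen, with the core of compound 1 otherwise unchanged: 4-methoxyphenyl in place of 5-carboxypyridin-3-yl on an aromatic nitrogen. Within the data shown here, the one measured step at this place, with 4-methoxybenzyl entering, is a step that the two limits leave unreadable from compound 1 to compound 2, so it offers no size to carry over. On that basis, no step beyond the scatter is expected in this assay, although a fall towards lower solubility remains possible and the reading may again be only a limit. The estimated change is a number no higher from compound 1 to compound 3 (the limit leaves the size open). For compound 3 the estimate is 3000 ug/mL. The expected range for this compound runs from 1000 ug/mL to 6000 ug/mL.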

Compound 3, solubility: 2600 ug/mL
Estimate against measurement, compound 3: 1.2-fold (0.06 log units) above, and the stated range covers the measured number.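

Among these compounds, compound 3 gives the first exact number: in this assay, compound 3 gives 2600 ug/mL, so this position on the aromatic nitrogen now has a measured anchor. Placing 4-methoxyphenyl where 5-carboxypyridin-3-yl stood gives an at least 1.1-fold lower number from compound 1 to compound 3 (0.06 log units; that floor lies within the scatter), and placing it where 4-methoxybenzyl stood gives an at least 1.1-fold lower number from compound 2 to compound 3 (0.06 log units; that floor lies within the scatter). These two steps give only floors, not sizes, and neither shows a change beyond the scatter, while the earlier step between the two limit compounds remains unreadable; the readings of the two earlier compounds are limits and not numbers: the limit of > 3000 ug/mL in this assay, at which 2 of the 3 values shown sit.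

The compounds shown leave open how far compound 1 and compound 2 actually stand from compound 3, and so whether either replacement has any real size in this read-out. They also leave open what an unsubstituted phenyl, an amine on the phenyl ring in place of methoxy, or a longer 4-methoxyphenethyl chain on the aromatic nitrogen would give, and whether any of these would yield an exact number clearly apart from compound 3.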